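Hydroxymethyl in place of formyl on the shared core

The compounds below may be only part of what the source reports. "The series", "measured", "known", "first", "only" and "open" are said of these compounds alone.

Going by the values given here, compound 2 `Cc1ccc2c(Cc3nn4c(C=O)c(-c5ccc(Cl)cc5)nc4s3)coc2c1` gives 3.6% in a functional assay on the whole organism (strain Wistar albino) for inhibition, with Rattus norvegicus as the target, read by paw edema, with a stated time of 0.5 h, at a dose of 100 mg/kg by the oral route (a lower number here means less inhibition, a higher number more inhibition at the dose given (going by the name of the read-out)), the lowest of the two numbers measured so far, though within the scatter of compound 1 `Cc1ccc2c(Cc3nn4cc(-c5ccc(Cl)cc5)nc4s3)coc2c1`, which in this assay gives 8.38%. Among the compounds with values here, the one measured step, a number 4.8 percentage points lower from compound 1 to compound 2 (within the scatter), stays within the scatter. Compound 3 `Cc1ccc2c(Cc3nn4c(CO)c(-c5ccc(Cl)cc5)nc4s3)coc2c1` follows from compound 2 by the change (hydroxymethyl in place of formyl on an aromatic carbon). Within the data shown here, no measured step swaps formyl for hydroxymethyl; the only step available, formyl for hydrogen, moved nothing beyond the scatter. A step of a number 2.4 percentage points higher from compound 2 to compound 3 (within the scatter) is therefore expected, none beyond the scatter. Compound 3 is estimated at 6% in this assay, between 0% and 16%.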

Compound 3, a percentage reported as inhibition, in the whole organism at one dose (the size of the read-out at that dose, not a potency): 9.61%
For compound 3 the middle estimate is 3.6 percentage points below the measured one; the range from low to high includes it.
By their numbers in this assay, from the lowest: compounds 2, 1 and 3 (each within the scatter of the next).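

At the aromatic carbon next to the ring nitrogen, the change from formyl to hydroxymethyl in this assay is a number 6 percentage points higher from compound 2 to compound 3 (within the scatter), and the change from hydrogen to hydroxymethyl is a number 1.2 percentage points higher from compound 1 to compound 3 (within the scatter). Hydrogen, formyl and hydroxymethyl at this position are therefore not separated in this read-out, and the hydrogen-bond donor that enters with hydroxymethyl brings no step beyond the scatter. No supporting data bear on this result.

On these data alone, whether an amine, a carboxylic acid or a longer chain at this position would give a step beyond the scatter remains open. As far as these compounds go, with a single dose and time, potency also remains open.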